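Methoxy to hydrogen on the benzyl ring: cytotoxicity notes

This account rests on a few compounds, and the source may have more. Where it says the series, first, only, none or still open, it means among the compounds named here.

Compound 1 `O=C(COc1ccc(-c2cc(=O)c3ccccc3o2)cc1)NC1CCN(Cc2ccccc2)CC1` and compound 2 `COc1ccc(CN2CCC(NC(=O)COc3ccc(-c4cc(=O)c5ccccc5o4)cc3)CC2)cc1` share the same core and differ at only one place. In a functional assay on HepG2 cells (Homo sapiens) for cytotoxicity, read by MTT assay, with a stated time of 72 h (a lower number here means a stronger inhibitor, a higher number a weaker inhibitor), compound 1 gives 15500 nM, while compound 2 gives 6800 nM. The change from compound 2 to compound 1 is hydrogen in place of methoxy on an aromatic carbon, and the step it produced was a 2.3-fold higher number from compound 2 to compound 1 (0.36 log units; beyond the scatter), a modest shift but one that lies beyond the usual scatter.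

Compound 3 `COc1ccc(CN2CCC(NC(=O)C(C)(C)Oc3ccc4c(=O)cc(-c5ccccc5)oc4c3)CC2)cc1` rests on a different core; the difference between the two cores is not broken down here. In this assay compound 3 gives 8700 nM, a value within the scatter of both compound 2 and compound 1, so no order among these three can be read from it.

Compound 4 `CC(C)(Oc1ccc2c(=O)cc(-c3ccccc3)oc2c1)C(=O)NC1CCN(Cc2ccccc2)CC1` has not yet been measured. The change from compound 3 to compound 4 is hydrogen in place of methoxy on an aromatic carbon, the same change at the same place as seen between compound 2 and compound 1; it occurs twice among the compounds shown. For the measured compounds named here, for compound 4 the expected step is a 2.1-fold higher number from compound 3 to compound 4 (0.32 log units; beyond the scatter), resting on the single earlier step of a 2.3-fold higher number from compound 2 to compound 1 (0.36 log units; beyond the scatter), with the caution that one pair on another core is a thin basis and the new core may not respond alike. Compound 4 is estimated at 18000 nM in this assay, with a plausible range from 8000 nM to 40000 nM.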

Compound 4, half-maximal inhibitory concentration: 14000 nM
For compound 4 the middle estimate is 1.3-fold (0.11 log units) above the measured one; the range from low to high includes it.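

On the core of compound 3, the loss of the methoxy group from the benzyl ring in this assay gives a 1.6-fold higher number from compound 3 to compound 4 (0.21 log units; within the scatter), so this step cannot be read as a real shift on its own. Set beside the earlier step, it gives no sign that the two cores respond differently to 4-methoxybenzyl to benzyl: the same change on two cores in this assay, a 2.3-fold higher number (0.36 log units; beyond the scatter) from compound 2 to compound 1 and a 1.6-fold higher number (0.21 log units; within the scatter) from compound 3 to compound 4, 1.4-fold (0.15 log units) apart, within the scatter of two such steps The steps point the same way, which is compatible with the change carrying over, but this does not show transfer of a fixed size, since only one of the two steps lies beyond the scatter and two pairs are a thin basis for any rule in this series.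

The compounds shown leave open whether other groups in the place of the methoxy, such as chlorine, fluorine, hydroxyl or a longer ethoxy chain, would behave alike on both cores, and whether any of them would move the number further than methoxy or hydrogen do. For the compounds shown here, they also hold no pair that separates the contribution of the two methyl groups on the carbon next to the amide carbonyl from the rest of the difference between the cores, so that part of the series remains unresolved.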